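Swapping methyls for chlorines on the aryl group

The compounds below may be only part of what the source reports. "The series", "measured", "known", "first", "only" and "open" are said of these compounds alone.

Three compounds share one core and differ only in the aryl group carried on an aromatic nitrogen. Compound 1 `Cc1cccc(-n2nncc2CN2C(=O)C3(C(C#N)=C(N)Oc4c3c3nc5ccccc5nc3c3ccccc43)c3ccccc32)c1` carries a 3-methylphenyl. In a functional assay on HCT-116 cells (Homo sapiens) for antiproliferative activity, read by MTT assay, with a stated time of 48 h (on this read-out lower numbers stand for stronger inhibition and higher numbers for weaker inhibition), compound 1 gives only a limit of the assay, > 50000 nM. Compound 2 `N#CC1=C(N)Oc2c(c3nc4ccccc4nc3c3ccccc23)C12C(=O)N(Cc1cnnn1-c1ccc(N)cc1)c1ccccc12` bears a 4-aminophenyl, and in this assay compound 2 gives 45200 nM. Compound 3 `Cc1cc(C)cc(-n2nncc2CN2C(=O)C3(C(C#N)=C(N)Oc4c3c3nc5ccccc5nc3c3ccccc43)c3ccccc32)c1` carries a 3,5-dimethylphenyl. In this assay compound 3 likewise gives only a limit, > 50000 nM. Compound 3 thus stands at the weak end of what has been measured because of the limit of > 50000 nM in this assay, at which 2 of the 3 values shown sit. The step of an at least 1.1-fold lower number from compound 1 to compound 2 (0.04 log units; that floor lies within the scatter) and the step of an at least 1.1-fold higher number from compound 2 to compound 3 (0.04 log units; that floor lies within the scatter) are each a floor within the scatter, and the step that the two limits leave unreadable from compound 1 to compound 3 cannot be read.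

Compound 4 `N#CC1=C(N)Oc2c(c3nc4ccccc4nc3c3ccccc23)C12C(=O)N(Cc1cnnn1-c1cc(Cl)ccc1Cl)c1ccccc12` is the next variant: 2,5-dichlorophenyl in place of 3,5-dimethylphenyl on an aromatic nitrogen. Among the measured compounds shown here, no measured step involves chlorine, and the aryl swaps measured so far moved the number little or not readably, so the step expected in this assay is a number no higher from compound 3 to compound 4 (the limit leaves the size open), none beyond the scatter. Compound 4 is therefore expected to give about 50000 nM in this assay, between 20000 nM and 150000 nM, quite possibly again only as a limit.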

Compound 4, half-maximal inhibitory concentration: > 50000 nM
Compound 4 was reported as a limit; the forecaster's own chance of this, stated with the estimate: 65%; the middle value lies on the limit itself.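

Chlorine now joins methyl on this aryl group, carried on an aromatic nitrogen of the five-membered ring, and the 2,5-dichlorophenyl of compound 4 still yields no measurable number. Among the compounds shown here, the steps linking compound 4 to compound 1 and to compound 3 cannot be read, and the only other step is an at least 1.1-fold higher number from compound 2 to compound 4 (0.04 log units; that floor lies within the scatter). In this assay, the series therefore gathers at its weak end, now with a chlorine-bearing aryl group as well as methyl-bearing ones: the limit of > 50000 nM in this assay, at which 3 of the 4 values shown sit.

From the compounds shown here alone, how far compound 1, compound 3 and compound 4 lie past that limit stays unknown, so these aryl groups cannot be ranked against one another. Going by these compounds, whether a carboxylic acid on the phenyl ring, or a longer chain in its place, would give a number clearly beyond the scatter remains open.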